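Bis-arylidene piperidinone dithiocarbamates: benzyl halide swap on MCF7

The source may report more compounds than this note shows. Statements on the series, on what has been measured and on what is new or still open speak of the compounds shown alone.

Compound 1 `Cc1ccc(/C=C2\CN(C(=S)SCc3cn(Cc4ccc(F)cc4)nn3)C/C(=C\c3ccc(C)cc3)C2=O)cc1` carries a 4-fluorobenzyl on the triazole and in a functional assay on MCF7 cells (Homo sapiens) for cytotoxicity, read by MTT assay, with a stated time of 24 h (on this read-out lower numbers stand for stronger inhibition and higher numbers for weaker inhibition), compound 1 gives 81600 nM. Compound 2 `Cc1ccc(/C=C2\CN(C(=S)SCc3cn(Cc4cccc(Cl)c4)nn3)C/C(=C\c3ccc(C)cc3)C2=O)cc1` is its 3-chlorobenzyl counterpart; in this assay compound 2 reaches only a limit, > 100000 nM, and no number. The step of an at least 1.2-fold higher number from compound 1 to compound 2 (0.08 log units; that floor lies within the scatter) is the change (3-chlorophenyl in place of 4-fluorophenyl on a saturated chain carbon bound to an aromatic nitrogen). Compound 3 `O=C1/C(=C/c2ccccc2F)CN(C(=S)SCc2cn(Cc3ccc(F)cc3)nn2)C/C1=C\c1ccccc1F` has a different core, and the difference between the cores of compound 1 and compound 3 is not broken down here; in this assay compound 3 gives 56900 nM, which sits within the scatter of compound 1.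

Compound 4 `O=C1/C(=C/c2ccccc2F)CN(C(=S)SCc2cn(Cc3cccc(Cl)c3)nn2)C/C1=C\c1ccccc1F` is not yet measured. It differs from compound 3 by 3-chlorophenyl in place of 4-fluorophenyl on a saturated chain carbon bound to an aromatic nitrogen, the same change at the same place as from compound 1 to compound 2. The expected step is a 1.3-fold higher number from compound 3 to compound 4 (0.10 log units; within the scatter), resting on the measured step of an at least 1.2-fold higher number from compound 1 to compound 2 (0.08 log units; that floor lies within the scatter), which ran into the limit (the limit of > 100000 nM in this assay, at which 1 of the 3 values shown sits). For compound 4 a value of 72000 nM is expected, estimated to fall between 40000 nM and 130000 nM.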

Compound 4, half-maximal inhibitory concentration: > 100000 nM
Compound 4: only a limit was reported; the forecaster's own chance of this, stated with the estimate: 35%; middle value at least 1.3-fold (0.14 log units) away from the limit.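

In this assay compound 4 reaches only a limit, > 100000 nM, and no number. On the core of compound 3, 3-chlorobenzyl in place of 4-fluorobenzyl therefore reads only as a floor, an at least 1.7-fold higher number from compound 3 to compound 4 (0.24 log units; that floor lies within the scatter). The two floors are compatible with the change carrying over from one core to the other, but they do not show that it has a real effect on either core, nor that its size is the same on both: the same change on two cores in this assay, an at least 1.2-fold higher number (0.08 log units; that floor lies within the scatter) from compound 1 to compound 2 and an at least 1.7-fold higher number (0.24 log units; that floor lies within the scatter) from compound 3 to compound 4; the limit leaves it open whether they differ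

From the compounds shown here alone, the upper end of this read-out leaves the 3-chlorobenzyl compounds without numbers, so the true size of the step stays open on both cores: the limit of > 100000 nM in this assay, at which 2 of the 4 values shown sit. Also open is how 4-chlorobenzyl, 3-fluorobenzyl or plain benzyl would read on these two cores, which could separate the choice of halogen from where it sits on the ring, and whether a benzyl carrying an amine or a carboxylic acid would give numbers rather than limits.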